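This account rests on a few compounds, and the source may have more. Where it says the series, first, only, none or still open, it means among the compounds named here.

In an ADME assay on the whole organism (Rattus norvegicus, strain Wister-Han) for pharmacokinetics, read by LC-MS, at a dose of 1 mg/kg by the intravenous route (on this read-out lower numbers stand for slow clearance and higher numbers for fast clearance), three compounds have been measured so far:

Compound 1 `Cc1ccncc1C(=O)N1CC(Oc2cncc(N3C(=O)c4ccc(Cl)cc4C3(C)C)c2)C1`: 15.8 mL/min/kg
Compound 2 `CCS(=O)(=O)N1CCC(c2cncc(N3C(=O)c4ccc(Cl)cc4C3(C)C)c2)CC1`: 29.7 mL/min/kg
Compound 3 `Cn1cc(C(=O)N2CC3(C2)CN(c2cncc(N4C(=O)c5ccc(Cl)cc5C4(C)C)c2)C3)cn1`: 6.4 mL/min/kg

Compound 1 lies within the usual scatter of compound 2, so these two cannot be told apart on this read-out. Compound 3 stands apart from both, and the gap between compound 1 and compound 3 is beyond the scatter, with compound 3 giving the lower number.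

The next compound is compound 4 `CCS(=O)(=O)N1CC(Oc2cncc(N3C(=O)c4ccc(Cl)cc4C3(C)C)c2)C1`, still unmeasured in this assay. It keeps the core of compound 1 and the four-membered non-aromatic ring, but ethylsulfonyl takes the place of (4-methylpyridin-3-yl)carbonyl on the amine nitrogen in that ring: ethylsulfonyl in place of (4-methylpyridin-3-yl)carbonyl on an amine nitrogen in a ring.

Going by the values given here, no measured pair differs in one place only, so the size of this step has no direct precedent. The nearest hint is compound 2, which also carries ethylsulfonyl and gives 29.7 mL/min/kg, though it differs from compound 1 elsewhere too. A small drift towards a higher number is therefore expected, but nothing beyond the scatter. The expected change is a 1.3-fold higher number from compound 1 to compound 4 (0.10 log units; within the scatter). For compound 4 the estimated clearance is 20 mL/min/kg, with an expected range of 10 mL/min/kg to 40 mL/min/kg.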

Compound 4, clearance: 3.8 mL/min/kg
Compound 4: middle estimate off by 5.3-fold (0.72 log units), on the high side; measured number below the stated range.
By their numbers in this assay, from the lowest: compounds 4 and 3 (each within the scatter of the next); then compounds 1 and 2 (each within the scatter of the next).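

In this assay the exchange of (4-methylpyridin-3-yl)carbonyl for ethylsulfonyl gives a 4.2-fold lower number from compound 1 to compound 4 (0.62 log units; beyond the scatter) and so provides the first step read at this position, one that lies beyond the scatter. It shows that the group on the amine nitrogen of the four-membered non-aromatic ring can by itself move clearance, and that a group with no ring, smaller in heavy atoms, can take the place of one holding a six-membered aromatic ring and give the lower number, with the count of hydrogen-bond acceptors unchanged. Nothing measured here bears on the reason for this shift.

Going by these compounds alone, the single step does not separate the arrival of the sulfonyl from the loss of the aromatic ring, and groups such as methylsulfonyl, a simple acetyl or an unsubstituted pyridinylcarbonyl on the same nitrogen would be needed to pull those apart. On these data alone, whether the step holds on other rings also stays open, as compound 2 and compound 3 each differ from compound 4 in more than one place.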